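Glycinamide series: rotarod dose after amino for ethyl

The source may report more compounds than this note shows. Statements on the series, on what has been measured and on what is new or still open speak of the compounds shown alone.

Measured so far:
compound 1, `CN(C)CC(=O)NCC(=O)N(C)c1ccc(Cl)cc1C(=O)c1ccccc1Cl`, 26 mg/kg
compound 2, `CCCC(=O)NCC(=O)N(C)c1ccc(Cl)cc1C(=O)c1ccccc1Cl`, 55.2 mg/kg

Among the measured compounds shown here, compound 2 holds the highest of the two numbers in a functional assay on the whole organism with Mus musculus as the target, in the rotarod test; a higher number here means that more compound is needed for the effect, a lower number that less compound is needed; the only neighbour, compound 1, sits at a lower value, and the step of a 2.1-fold higher number from compound 1 to compound 2 (0.33 log units; beyond the scatter) lies beyond the scatter.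

Compound 3, `CN(C(=O)CNC(=O)CN)c1ccc(Cl)cc1C(=O)c1ccccc1Cl`, is not yet measured. It differs from compound 2 by amino in place of ethyl on a saturated chain carbon bound to a carbonyl carbon.

For the measured compounds named here, only one measured step touches this position. Compound 1, which carries dimethylamino there, gave the lower number, and exchanging that group for ethyl raised the dose, a 2.1-fold higher number from compound 1 to compound 2 (0.33 log units; beyond the scatter). Compound 3 again carries a nitrogen group at this place, so a reversal of roughly that size is expected, the step of a 1.8-fold lower number from compound 2 to compound 3 (0.26 log units; within the scatter) being the estimate.

For compound 3 the expected value in this assay is 30 mg/kg, with a range from 15 mg/kg to 65 mg/kg.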

Compound 3, dose for half-maximal effect: 27.7 mg/kg
Compound 3: the middle estimate sits 1.1-fold (0.03 log units) above what was measured, and the stated range covers the measured number.
By their numbers in this assay, from the lowest: compounds 1, 3 and 2 (each within the scatter of the next, the first and the last beyond it).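

In this assay, amino and dimethylamino on a saturated chain carbon bound to a carbonyl carbon cannot be told apart, with a 1.1-fold higher number from compound 1 to compound 3 (0.03 log units; within the scatter), so the size of the nitrogen group shows no effect here across these two compounds. Among the compounds shown here, the other comparison, a 2.0-fold lower number from compound 2 to compound 3 (0.30 log units; within the scatter), also stays within the scatter, so amino cannot be separated from ethyl, although dimethylamino can, and the single step beyond the scatter at this position remains the one between dimethylamino and ethyl. Nothing measured bears on the reason for these values.

On these data alone, whether the nitrogen matters at all stays open, since a hydroxyl group or a methoxy group at this place would be needed to compare with amino. A methylamino group, a longer amine chain or a carboxylic acid could also show how far the values at this position extend.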